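Esterifying the Hydroxymethyl of Compound 1

The compounds below may be only part of what the source reports. "The series", "measured", "known", "first", "only" and "open" are said of these compounds alone.

Compound 1 `CCc1cccc2c(OC)c(-c3occ(C)c3CO)ccc12` sits at the limit of > 10 ug/mL in this assay, at which 1 of the 2 values shown sits. In a functional assay on ZR-75-1 cells (Homo sapiens) for cytotoxicity, read by MTT assay, with a stated time of 72 h (a lower number here means that less compound is needed, a higher number that more compound is needed for the effect), compound 1 yields only a limit, > 10 ug/mL, rather than a number. Compound 2 `CCOc1c(-c2occ(C)c2CO)ccc2c(CC)cccc12` in this assay gives 1.4 ug/mL, a step of an at least 7.1-fold lower number from compound 1 to compound 2 (0.85 log units; beyond the scatter). Compound 3 `CCc1cccc2c(OC)c(-c3occ(C)c3COC(=O)CCN(CC)CC)ccc12` differs from compound 1 by (2-(diethylamino)ethyl)carbonyl in place of hydrogen on an oxygen on a saturated carbon. Going by the values given here, no measured step touches this position; the one known step alters the alkoxy group and offers no direct guide, and since compound 1 is fixed only by a limit, the size and direction of an at least 1.6-fold lower number from compound 1 to compound 3 (0.22 log units; that floor lies within the scatter) are expected with little confidence. Compound 3 is estimated at 6 ug/mL, between 1.5 ug/mL and 25 ug/mL.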

Compound 3, concentration for half-maximal effect: 1.7 ug/mL
Estimate against measurement, compound 3: 3.5-fold (0.55 log units) above; the range from low to high includes it.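

Going by these compounds alone, putting (2-(diethylamino)ethyl)carbonyl in place of hydrogen on this oxygen gives an at least 5.8-fold lower number from compound 1 to compound 3 (0.76 log units; beyond the scatter), so the alkoxy group is no longer the only place on compound 1 where a change is seen to lower the number in this assay. That size is only a floor, and compound 1 stands at a limit, not a number: the limit of > 10 ug/mL in this assay, at which 1 of the 3 values shown sits.

On these data alone, whether the step belongs to the ester link or to the diethylamino end remains open. So does what a plain acetyl group, a longer chain or a piperidine in place of the diethylamino end would give on this oxygen.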